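Acylsulfonamide variation at the amide nitrogen of the indole core

This account rests on a few compounds, and the source may have more. Where it says the series, first, only, none or still open, it means among the compounds named here.

Going by the values given here, compound 1 `Cc1cc(C)cc(S(=O)(=O)c2c(C(=O)N[C@@H]3CCN(S(C)(=O)=O)C3)[nH]c3ccc(Cl)cc23)c1` gives 24000 nM in an ADME assay on MT4 cells (Homo sapiens) for cytotoxicity, read by MTT assay, with a stated time of 5 days (a higher number here means that more compound is tolerated, a lower number that less compound is tolerated), the lowest of the three numbers so far. Compound 2 `Cc1cc(C)cc(S(=O)(=O)c2c(C(=O)NC3CN(Cc4cccnc4)C3)[nH]c3ccc(Cl)cc23)c1` gives 36000 nM and compound 3 `Cc1cc(C)cc(S(=O)(=O)c2c(C(=O)NS(C)(=O)=O)[nH]c3ccc(Cl)cc23)c1` gives 40200 nM, and both steps are small: a 1.5-fold higher number from compound 1 to compound 2 (0.18 log units; within the scatter) and a 1.7-fold higher number from compound 1 to compound 3 (0.22 log units; within the scatter). Compound 4 `Cc1cc(C)cc(S(=O)(=O)c2c(C(=O)NS(=O)(=O)c3ccccc3)[nH]c3ccc(Cl)cc23)c1` differs from compound 1 by phenylsulfonyl in place of 1-(methylsulfonyl)pyrrolidin-3-yl on an amide-type nitrogen. Among the compounds with values here, the closest precedent is the methylsulfonyl replacement, where a 1.7-fold higher number from compound 1 to compound 3 (0.22 log units; within the scatter) stayed within the scatter, as did a 1.1-fold higher number from compound 2 to compound 3 (0.05 log units; within the scatter); the three substituents on this nitrogen thus leave the read-out essentially flat. No step beyond the scatter is expected here either. For compound 4 the estimate is 32000 nM (range 13000 nM to 80000 nM), an expected step of a 1.3-fold higher number from compound 1 to compound 4 (0.12 log units; within the scatter).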

Compound 4, half-maximal cytotoxic concentration: 167000 nM
Beside the measured number, compound 4's estimate is 5.2-fold (0.72 log units) below it; measured number above the stated range.
By their numbers in this assay, from the lowest: compounds 1, 2 and 3 (each within the scatter of the next); then compound 4.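

In this assay, the substituent on this amide-type nitrogen no longer leaves the read-out flat: phenylsulfonyl stands apart from the two non-acyl-sulfonamide groups, with a 7.0-fold higher number from compound 1 to compound 4 (0.84 log units; beyond the scatter) and a 4.6-fold higher number from compound 2 to compound 4 (0.67 log units; beyond the scatter). Phenyl in place of methyl on a sulfonyl sulfur gives a 4.2-fold higher number from compound 3 to compound 4 (0.62 log units; beyond the scatter), so the sulfonyl on this nitrogen does not alone set the number, and the group on the sulfur matters. Nothing available accounts for this step.

Open, from the compounds shown here alone, is whether benzylsulfonyl or aminophenylsulfonyl on this nitrogen would keep the number of compound 4. Also open, going by these compounds, is whether a benzoyl group would do so without the sulfonyl.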